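The source may report more compounds than this note shows. Statements on the series, on what has been measured and on what is new or still open speak of the compounds shown alone.

Within the data shown here, compound 1 `COc1cccc(OC)c1OCCNCCOc1ccccc1OCc1ccccc1Cl` gives 8.59 in a functional assay on thoracic aorta for antagonist activity at Alpha-1D adrenergic receptor (Rattus norvegicus) (a lower number here means a less potent compound, a higher number a more potent compound, by a factor of ten per unit of this negative logarithm), the lowest of the three numbers measured so far, though both neighbours sit within the scatter of it: compound 2 `COc1cccc(OC)c1OCCNCCOc1ccccc1OCc1cccc(Cl)c1` gives 8.72 and compound 3 `COc1ccccc1COc1ccccc1OCCNCCOc1c(OC)cccc1OC` gives 8.86. The unmeasured compound 4 `COc1cccc(COc2ccccc2OCCNCCOc2c(OC)cccc2OC)c1` differs from compound 1 by 3-methoxyphenyl in place of 2-chlorophenyl on a saturated chain carbon bound to an oxygen on an aromatic ring. Among the measured compounds shown here, two measured steps bear on this: a number 0.13 log units higher from compound 1 to compound 2 (within the scatter), which moves the ring substituent, and a number 0.27 log units higher from compound 1 to compound 3 (within the scatter), which swaps chloro for methoxy. Both were small, so compound 4, which combines both kinds of alteration, is expected to show at most a small rise in this assay, estimated as a number 0.16 log units higher from compound 1 to compound 4 (within the scatter). Compound 4 is therefore estimated at 8.75, with a range from 8.45 to 9.05.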

Compound 4, negative logarithm of the antagonist equilibrium constant: 9.12
Compound 4: middle estimate off by 0.37 log units, on the low side; the measured number lies above the stated range.
By their numbers in this assay, from the lowest: compounds 1, 2, 3 and 4 (each within the scatter of the next, the first and the last beyond it).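

In this assay, among these compounds, the 3-methoxyphenyl group gives the first steps beyond the scatter: a number 0.53 log units higher from compound 1 to compound 4 (beyond the scatter) and a number 0.40 log units higher from compound 2 to compound 4 (beyond the scatter). Against the 2-methoxyphenyl group, however, the difference stays small, with a number 0.26 log units higher from compound 3 to compound 4 (within the scatter). Methoxy in place of chloro also reads alike in both settings: the same change on two cores in this assay, a number 0.27 log units higher (within the scatter) from compound 1 to compound 3 and a number 0.40 log units higher (beyond the scatter) from compound 2 to compound 4, 0.13 log units apart, within the scatter of two such steps.

The compounds shown carry only chloro and methoxy on this ring, so an amine or a carboxylic acid there remains an open case. Going by these compounds, a longer chain in place of the single carbon linking this ring to oxygen is equally open.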